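Swapping methyl for methoxy on the thiadiazole-side phenyl

The source may hold more compounds than are shown below. What is called first, only, known or untested is meant among the compounds shown, and "the series" means these compounds.

Among the measured compounds shown here, compound 2 `Cc1ccc(-c2nnc(Nc3csc(-c4ccccc4)c3)s2)cc1` gives the only plain number in a functional assay on MCF7 cells (Homo sapiens) for inhibition, read by colorimetric assay and MTT assay, with a stated time of 72 h (a higher number here means a weaker inhibitor, a lower number a stronger inhibitor), so far, 34000 nM. Compound 1 `COc1ccc(-c2cc(Nc3nnc(-c4ccc(C)cc4)s3)cs2)cc1` reaches only a limit of the assay in this assay, > 100000 nM. Compound 3 `Cc1ccc(-c2cc(Nc3nnc(-c4ccc(C)cc4)s3)cs2)cc1` has no result in this assay, "not determined" (no result reported). For the measured compounds named here, the one measured step, an at least 2.9-fold lower number from compound 1 to compound 2 (0.46 log units; beyond the scatter), is the sole guide, and it rests on (the limit of > 100000 nM in this assay, at which 1 of the 3 values shown sits). Compound 4 `COc1ccc(-c2nnc(Nc3csc(-c4ccccc4)c3)s2)cc1` differs from compound 2 by methoxy in place of methyl on an aromatic carbon. Going by the values given here, the measured step concerns a methoxy on a different aromatic carbon, so it bears on the new change only loosely; still, it is the only evidence that a methoxy, where a methyl or hydrogen stood, is unlikely to lower the number, and an upward move of modest size or none beyond the scatter is expected. Compound 4 is therefore estimated at 55000 nM, within 20000 nM to 150000 nM, which means an expected step of a 1.6-fold higher number from compound 2 to compound 4 (0.21 log units; within the scatter).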

Compound 4, half-maximal inhibitory concentration: 60000 nM
For compound 4 the middle estimate is 1.1-fold (0.04 log units) below the measured one, within the range that was stated.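

Methoxy in place of methyl, para to a large group, gives a 1.8-fold higher number from compound 2 to compound 4 (0.25 log units; within the scatter) in this assay, so at this position the two groups cannot be told apart. Unlike the earlier step, this one joins two plain numbers, and the hydrogen-bond acceptor that enters with methoxy brings no shift beyond the scatter. The earlier step, which concerns a methoxy on a different aromatic carbon, has no such footing and rests on a limit: the limit of > 100000 nM in this assay, at which 1 of the 4 values shown sits.

Whether this position responds to anything other than these two groups stays open, since the compounds shown include no amine, carboxylic acid or longer chain there. Compound 1 and compound 4 differ in more than one place, so they do not show whether methoxy behaves alike at the two positions.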